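From 2-fluorophenyl to 4-fluorophenyl

The source may report more compounds than this note shows. Statements on the series, on what has been measured and on what is new or still open speak of the compounds shown alone.

In a functional assay on HepG2 cells (Homo sapiens) for antiproliferative activity, read by MTT assay, with a stated time of 24 h (on this read-out higher numbers stand for weaker inhibition and lower numbers for stronger inhibition), compound 1 `c1ccc(CSc2nnc(-c3ccc4c(c3)OCCO4)n2-c2ccccc2)cc1`, which carries no halogen, gives 5960 nM. Compound 2 `Clc1ccccc1CSc1nnc(-c2ccc3c(c2)OCCO3)n1-c1ccccc1` gives 970 nM, and compound 3 `Fc1ccccc1CSc1nnc(-c2ccc3c(c2)OCCO3)n1-c1ccccc1` gives 810 nM. These last two cannot be told apart, as a 1.2-fold lower number from compound 2 to compound 3 (0.08 log units; within the scatter) shows, so compound 3 stands level with compound 2 and well clear of compound 1.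

Compound 4 `Fc1ccc(CSc2nnc(-c3ccc4c(c3)OCCO4)n2-c2ccccc2)cc1` has the same atoms as compound 3, joined differently: 4-fluorophenyl in place of 2-fluorophenyl on a saturated chain carbon bound to a sulfur. For the measured compounds named here, no measured step moves a halogen from one place to another. The closest evidence is the gain on adding one, namely a 6.1-fold lower number from compound 1 to compound 2 (0.79 log units; beyond the scatter) and a 7.4-fold lower number from compound 1 to compound 3 (0.87 log units; beyond the scatter). Since compound 4 also carries a fluoro group, it is expected to keep most of that gain, though the data cannot show how much of it depends on placement. The expected change is a small one towards a higher number, a 1.6-fold higher number from compound 3 to compound 4 (0.21 log units; within the scatter), and it may not exceed the scatter. Compound 4 is estimated at 1300 nM, with a likely range of 400 nM to 4000 nM.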

Compound 4, half-maximal inhibitory concentration: 1020 nM
Estimate against measurement, compound 4: 1.3-fold (0.11 log units) above, and the stated range covers the measured number.
By their numbers in this assay, from the lowest: compounds 3, 2 and 4 (each within the scatter of the next); then compound 1.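

In this assay, 4-fluorophenyl in place of 2-fluorophenyl on a saturated chain carbon bound to a sulfur gives no difference that can be resolved (a 1.3-fold higher number from compound 3 to compound 4 (0.10 log units; within the scatter)), and the same holds for 4-fluorophenyl in place of 2-chlorophenyl (a 1.1-fold higher number from compound 2 to compound 4 (0.02 log units; within the scatter)). The gain over the unsubstituted compound 1 therefore does not belong to the 2-fluorophenyl or 2-chlorophenyl group alone, since it also appears with 4-fluorophenyl (a 5.8-fold lower number from compound 1 to compound 4 (0.77 log units; beyond the scatter)). Nothing available explains this gain or its insensitivity to where the fluoro group sits.

From the compounds shown here alone, whether the gain needs a halogen at all remains open, as a methoxy group or an amine on this ring could show. So does the question of whether a bromo group would match the chloro and fluoro compounds.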